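The source may hold more compounds than are shown below. What is called first, only, known or untested is meant among the compounds shown, and "the series" means these compounds.

Working notes on the series, read in a functional assay on the whole organism with Rattus norvegicus as the target; a lower number here means that less compound is needed, a higher number that more compound is needed for the effect. Compound 1 (`CCOC(=O)C(=O)Nc1nc(-c2ccc(F)cc2)cs1`) gives > 10 mg/kg, which is a limit and not a number. Compound 2 (`CCOC(=O)C(=O)Nc1nc(-c2ccc(Sc3ccccc3)cc2)cs1`) gives > 3 mg/kg, which is also a limit and not a number. Among the measured compounds shown here, compound 2 therefore has no numerical standing, and the only other value available, that of compound 1, is a limit too.

Compound 3 (`CCCC(=O)Nc1ccc(-c2csc(NC(=O)C(=O)OCC)n2)cc1`) keeps the shared core and differs from compound 2 as follows: (propylcarbonyl)amino in place of phenylsulfanyl on an aromatic carbon. The group sits on an aromatic carbon of a six-membered aromatic ring of carbon only, para to a large group.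

For the measured compounds named here, the only measured step bearing on this change is a step that the two limits leave unreadable from compound 1 to compound 2, at the same place on the ring. That step has no readable size, so it gives neither a magnitude nor a direction to carry over to this assay. The expectation is therefore only loosely anchored and wide, and a further limit remains quite possible.

Going by the values given here, the expected step is a step that the limit leaves unreadable from compound 2 to compound 3, an estimate with no measured step to support its size. For compound 3 the estimated value is 4 mg/kg, with an expected range from 0.5 mg/kg to 30 mg/kg.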

Compound 3, dose for half-maximal effect: > 10 mg/kg
Compound 3 was reported as a limit; the forecaster's own chance of this, stated with the estimate: 55%; middle value at least 2.5-fold (0.39 log units) from the limit.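

In this assay compound 3 gives > 10 mg/kg, which is a limit and not a number. Among the compounds shown here, the steps linking compound 3 to compound 1 and compound 2 cannot be read, so this result yields no new step. The compounds shown leave open whether fluoro, phenylsulfanyl or (propylcarbonyl)amino on the aromatic carbon changes the dose needed, in either direction or by any size.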